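Swapping the anilino for piperazin-1-yl on the shared core

A few compounds are considered here, and "the series" means these few. Any claim that something is new, unique, unknown or untested is made for them only; others in the source may bear on it.

Measured compounds:
compound 1 `c1cc2c(ccn2C2COC2)cc1-c1ccc2oc(NC3CCCCC3)nc2c1`, 579 nM
compound 2 `Cn1ncc2cc(-c3ccc4oc(NC5CCCCC5)nc4c3)ccc21`, 61 nM
compound 3 `Cn1ccc2cc(-c3ccc4oc(Nc5ccccc5)nc4c3)ccc21`, 48 nM

These three compounds share a core and were tested in an assay on HEK293 cells for inhibition of Fatty-acid amide hydrolase 1 (Homo sapiens), read by fluorescence; on this read-out higher numbers stand for weaker inhibition and lower numbers for stronger inhibition. Compound 3 gives the lowest of the three numbers, 48 nM. Compound 2 gives 61 nM, a number that sits within the usual scatter of compound 3, so the two cannot be ordered. Compound 1 gives 579 nM, a gap that lies well beyond the scatter; compound 1 also differs from the others in more than one place, so no single change can be read from it.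

The next compound, compound 4 `Cn1ccc2cc(-c3ccc4oc(N5CCNCC5)nc4c3)ccc21`, has not yet been measured in this assay. It differs from compound 3 in one place: piperazin-1-yl in place of anilino on an aromatic carbon.

For the measured compounds named here, no measured pair shows this kind of change, so the expectation rests only on the values above. Since the anilino and the cyclohexylamino of compound 2 give numbers within the scatter of each other, while the piperazin-1-yl is a different kind of group, the estimated step is a 6.3-fold higher number from compound 3 to compound 4 (0.80 log units; beyond the scatter), toward a weaker inhibition. Compound 4 is therefore expected to give about 300 nM, within a range from 60 nM to 1500 nM.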

Compound 4, half-maximal inhibitory concentration: > 1000 nM
Compound 4 gave a limit, no number; the forecaster's own chance of this, stated with the estimate: 10%; middle value at least 3.3-fold (0.52 log units) from the limit.
By their numbers in this assay, from the lowest: compounds 3 and 2 (each within the scatter of the next); then compound 1. At a limit, above all of these: compound 4.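

In this assay, for the compounds shown here, putting piperazin-1-yl in place of anilino gives an at least 20-fold higher number from compound 3 to compound 4 (1.31 log units; beyond the scatter), and this is the first change in the set that can be read at a single place. It shows that the group on this aromatic carbon, next to the ring nitrogen and next to the ring oxygen, can strongly change the read-out, something compounds 1, 2 and 3 could not show, since they differ from one another in more than one place. For compound 4 the read-out is > 1000 nM, which is a limit of the assay and not a number, so the step gives only the smallest size the change can have: the limit of > 1000 nM in this assay, at which 1 of the 4 values shown sits.

The swap alters several things at once, including an aromatic ring of carbon only giving way to a non-aromatic ring with two hetero atoms, and these compounds do not tell which of these differences matters. A piperidin-1-yl or a morpholin-4-yl at this position, or a cyclohexylamino on the core of compound 3, would help separate them.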